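Swapping a ring amine for dimethylamino on a weak series

A few compounds are considered here, and "the series" means these few. Any claim that something is new, unique, unknown or untested is made for them only; others in the source may bear on it.

Measured compounds:
compound 1, `O=C1N=C(N2CCOCC2)CN1c1ccccc1`: 121 mg/kg
compound 2, `O=C1N=C(N2CCCC2)CN1c1ccc(Cl)cc1`: > 300 mg/kg
compound 3, `CN1CCN(C2=NC(=O)N(c3ccc(Cl)cc3)C2)CC1`: > 300 mg/kg

The three measured compounds share a core and differ in the amine attached to it and in the aryl group. In a functional assay on the whole organism (strain NMRI BR) with Mus musculus as the target (a higher number here means that more compound is needed for the effect, a lower number that less compound is needed), compound 1 gives 121 mg/kg. For compound 2 the assay reports only a limit, > 300 mg/kg, which is not a number. Compound 3 likewise gives only a limit, > 300 mg/kg. Compound 2 therefore stands at the limit of > 300 mg/kg in this assay, at which 2 of the 3 values shown sit, so nothing is known about how far beyond that point it lies.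

Compound 4, `CN(C)C1=NC(=O)N(c2ccc(Cl)cc2)C1`, is not yet measured. It differs from compound 2 by dimethylamino in place of pyrrolidin-1-yl on a carbon with a double bond to nitrogen. Among the measured compounds shown here, no step between measured compounds isolates this kind of change, so its size and direction cannot be read from the data. Compound 4 is expected to behave much like compound 2, with a step that the limit leaves unreadable from compound 2 to compound 4 that stays near the limit. The estimate for compound 4 in this assay is 400 mg/kg, with a range from 150 mg/kg to 1200 mg/kg, and a fair chance that only a limit is reported again.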

Compound 4, dose for half-maximal effect: > 300 mg/kg
Compound 4: only a limit was reported (the forecaster's own chance of this, stated with the estimate: 65%); the middle value lies beyond the limit too.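

In this assay, among the compounds shown here, compound 2 and compound 4 each give only a limit, so no step between them can be read: the limit of > 300 mg/kg in this assay, at which 3 of the 4 values shown sit. The compounds shown leave open whether dimethylamino in place of pyrrolidin-1-yl changes the dose needed, and how far beyond the limit either compound lies.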